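From 2-chlorophenyl to 3-fluorophenyl on a shared core

This account rests on a few compounds, and the source may have more. Where it says the series, first, only, none or still open, it means among the compounds named here.

Compound 1 `OC(c1ccc(Cl)cc1)(c1cncnc1)c1ccccc1F`: > 100000 nM (a limit of the assay)
Compound 2 `OC(c1ccc(Cl)cc1)(c1ccc(C(F)(F)F)cc1)c1cncnc1`: 66800 nM
Compound 3 `OC(c1ccc(Cl)cc1)(c1cccnc1)c1ccccc1Cl`: 61300 nM

These values come from an ADME assay on L6 cells (Rattus norvegicus) for cytotoxicity, read by resazurin assay, with a stated time of 72 h; on this read-out lower numbers stand for stronger inhibition and higher numbers for weaker inhibition. Compound 1 gives > 100000 nM, which is a limit of the assay and not a number. Compound 2 gives 66800 nM and compound 3 gives 61300 nM, and these two values lie within the usual scatter of each other.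

Compound 4 `OC(c1ccc(Cl)cc1)(c1cccnc1)c1cccc(F)c1` is not yet measured. Compared with compound 3, it has 3-fluorophenyl in place of 2-chlorophenyl on a saturated chain carbon bound to two aromatic carbons and an oxygen on a saturated carbon.

For the measured compounds named here, no two measured compounds differ in just one place, so no measured step can serve as a guide. The expectation therefore rests on the value of compound 3, 61300 nM, and no change beyond the scatter is expected in this assay. The expected step is a 1.1-fold higher number from compound 3 to compound 4 (0.03 log units; within the scatter). For compound 4, the estimated value is 65000 nM, with an expected range from 30000 nM to 100000 nM.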

Compound 4, half-maximal inhibitory concentration: 66000 nM
Compound 4: middle estimate off by 1.0-fold (0.01 log units), on the low side, and the stated range covers the measured number.
By their numbers in this assay, from the lowest: compounds 3, 4 and 2 (each within the scatter of the next). At a limit, above all of these: compound 1.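

In this assay, the only pair shown that differs in one place gives a 1.1-fold higher number from compound 3 to compound 4 (0.03 log units; within the scatter). On the saturated chain carbon bound to two aromatic carbons and an oxygen on a saturated carbon, 3-fluorophenyl in place of 2-chlorophenyl therefore gives no difference that stands out from the scatter, although this single swap alters both the halogen and where it sits on the ring, and one step cannot separate those two alterations. Compound 1 remains a limit of the assay and not a number, and it is the only such case here: the limit of > 100000 nM in this assay, at which 1 of the 4 values shown sits.

As far as these compounds go, it remains open whether 3-chlorophenyl on the same core would separate the halogen from its place on the ring. Also open, from the compounds shown here alone, is whether a group of another kind at this carbon, such as an amine or a carboxylic acid in place of the aromatic ring, would give a number beyond the scatter.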